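A few compounds are considered here, and "the series" means these few. Any claim that something is new, unique, unknown or untested is made for them only; others in the source may bear on it.

Measured in an ADME assay on a cell-free system (plasma, Rattus norvegicus) for protein binding:
- compound 1 `Cc1ccc(-c2cc(C(=O)N[C@H](C)c3nc(C)no3)cc(-c3ncccc3F)c2)nc1`: 99.6%
- compound 2 `C[C@@H](NC(=O)c1cc(-c2ccc(Cl)cn2)cc(C(C)(C)O)c1)c1ccc(C(F)(F)F)[n+]([O-])c1`: 76.2%

Compound 1 has the lower unbound fraction of the two, and its gap to compound 2 lies beyond the scatter. Compound 3 `Cc1ccc(-c2cc(C(=O)N[C@H](C)c3ccc(F)c[n+]3[O-])cc(-c3ncccc3F)c2)nc1` carries one change from compound 1: a group of 8 heavy atoms (5 carbon, 1 nitrogen, 1 oxygen, 1 fluorine; one six-membered aromatic ring with 1 hetero atom) in place of a group of 6 heavy atoms (3 carbon, 2 nitrogen, 1 oxygen; one five-membered aromatic ring with 3 hetero atoms), on a saturated chain carbon bound to an amide-type nitrogen and a saturated chain carbon. Among the compounds with values here, no one-place step has been measured, so the expectation rests on thin data. Compound 1 and compound 2 differ in more than one place, and compound 2 reads 76.2%, which leaves room for more free compound. A modest step towards a higher unbound fraction is expected, estimated at a 6.3-fold higher unbound fraction from compound 1 to compound 3 (0.80 log units; beyond the scatter). For compound 3 the estimated value is 97.5%, with an expected range of 91% to 99.5%.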

Compound 3, plasma protein binding: 90.4%
Estimate against measurement, compound 3: 3.8-fold (0.58 log units) (unbound fraction) below; measured number below the stated range.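

In this assay, the saturated chain carbon bound to an amide-type nitrogen and a saturated chain carbon is a place where the read-out responds strongly: putting the six-membered aromatic ring with 1 hetero atom in place of 3-methyl-1,2,4-oxadiazol-5-yl gives a 24-fold higher unbound fraction from compound 1 to compound 3 (1.38 log units; beyond the scatter) and is a large step. The high binding of compound 1 therefore does not rest on the shared core alone. Nothing measured here bears on why this change has this effect. On these data alone, whether an amine or a carboxylic acid at this place would free more compound remains open.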